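Methyl for Hydrogen and Half-Life in Mouse Liver Microsomes

The source may report more compounds than this note shows. Statements on the series, on what has been measured and on what is new or still open speak of the compounds shown alone.

Compound 1 `CC(C)N/C(=N\c1nccn1C(C)C)Nc1ccc(Cl)c(Cl)c1`: 0.0983 h
Compound 2 `CC(C)N/C(=N\c1nccn1C(C)(C)C)Nc1ccc(Cl)c(Cl)c1`: 0.15 h
Compound 3 `CC(C)n1ccnc1/N=C(/NC(=O)C(C)(C)C)Nc1ccc(Cl)c(Cl)c1`: only a limit of the assay, > 1 h

In an in vitro ADME assay on microsomes from liver (Mus musculus) for metabolic stability, read by LC-MS, tested at 1 uM (a lower number here means that the compound disappears faster, a higher number that the compound lasts longer), compound 1 gives 0.0983 h and compound 2 gives 0.15 h. The change between them is methyl in place of hydrogen on a saturated chain carbon bound to an aromatic nitrogen and two saturated chain carbons, and it made a 1.5-fold higher number from compound 1 to compound 2 (0.18 log units; within the scatter). For compound 3 the assay reports only a limit, > 1 h, and (the limit of > 1 h in this assay, at which 1 of the 3 values shown sits). How the core of compound 3 differs from that of compound 1 is not broken down here.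

Compound 4 `CC(C)(C)C(=O)N/C(=N/c1nccn1C(C)(C)C)Nc1ccc(Cl)c(Cl)c1` has not yet been measured in this assay. Among the compounds with values here, it differs from compound 3 by methyl in place of hydrogen on a saturated chain carbon bound to an aromatic nitrogen and two saturated chain carbons, the same change as the one from compound 1 to compound 2. Since compound 3 already sits at the limit (the limit of > 1 h in this assay, at which 1 of the 3 values shown sits), compound 4 is expected to stay there too, giving an estimated 1.5 h, between 0.7 h and 4 h. This expectation means a step that the limit leaves unreadable from compound 3 to compound 4, resting on the small step of a 1.5-fold higher number from compound 1 to compound 2 (0.18 log units; within the scatter).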

Compound 4, half-life: > 1 h
Compound 4: no number, only a limit; the forecaster's own chance of this, stated with the estimate: 70%; the middle value does not contradict the limit.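

In this assay, compound 3 and compound 4 both give only a limit, so no step can be read between them: the limit of > 1 h in this assay, at which 2 of the 4 values shown sit.

The compounds shown leave open how long either compound actually lasts, and whether isopropyl to tert-butyl changes the half-life here at all.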